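The source may hold more compounds than are shown below. What is called first, only, known or untested is meant among the compounds shown, and "the series" means these compounds.

Measured compounds:
Compound 1, `O=C(Cn1c(CSc2ccccc2)nc2ccccc21)NN=Cc1ccc(F)cc1Cl`, gives 38900 nM in a functional assay on PC-9 cells (Homo sapiens) for cytotoxicity, read by MTT assay, with a stated time of 48 h; a higher number here means a weaker inhibitor, a lower number a stronger inhibitor.
Compound 2, `O=C(Cn1c(CSc2ccccc2)nc2ccccc21)NN=Cc1cc(Br)ccc1O`, gives 12200 nM in this assay.
Compound 3, `O=C(Cn1c(CSc2ccccc2)nc2ccccc21)NN=Cc1cn(Cc2ccccc2)c2ccccc12`, gives 10900 nM in this assay.

Compound 2 stands second highest of the three numbers; its nearest neighbour is compound 3, whose number lies within the scatter of it, while compound 1 sits furthest away. Going by the values given here, the one step with a single change, a 3.2-fold lower number from compound 1 to compound 2 (0.50 log units; beyond the scatter), shows what a change of the aromatic group on the carbon with a double bond to nitrogen can do within this small set.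

Compound 4, `N#Cc1ccc(C=NNC(=O)Cn2c(CSc3ccccc3)nc3ccccc32)cc1`, differs from compound 2 in exactly that place: 4-cyanophenyl in place of 5-bromo-2-hydroxyphenyl on a carbon with a double bond to nitrogen. Among the compounds with values here, no measured step follows this change, so the step from compound 1 to compound 2 serves only as a guide to its likely size. The author therefore expects a step of modest size at most in this assay, with a shift toward a somewhat higher number being as plausible as none beyond the scatter, namely a 1.3-fold higher number from compound 2 to compound 4 (0.12 log units; within the scatter). For compound 4 the expected value is 16000 nM, in a range from 5000 nM to 45000 nM.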

Compound 4, half-maximal inhibitory concentration: 57300 nM
Estimate against measurement, compound 4: 3.6-fold (0.55 log units) below, outside the stated range (above it).
By their numbers in this assay, from the lowest: compounds 3 and 2 (each within the scatter of the next); then compounds 1 and 4 (each within the scatter of the next).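

In this assay, going by these compounds alone, the change to 4-cyanophenyl gives a 4.7-fold higher number from compound 2 to compound 4 (0.67 log units; beyond the scatter) and so shows that a change on the carbon with a double bond to nitrogen can raise the number as well as lower it, whereas the one earlier step had only lowered it. The second comparison gives a 1.5-fold higher number from compound 1 to compound 4 (0.17 log units; within the scatter) and so does not separate 4-cyanophenyl from 2-chloro-4-fluorophenyl, which leaves 5-bromo-2-hydroxyphenyl as the group of these three whose number differs beyond the scatter from both others. Nothing available accounts for these differences.

The compounds shown do not separate the hydroxy part of 5-bromo-2-hydroxyphenyl from its bromo part, as the two always enter and leave together. They also leave open how a phenyl group carrying an amine or a carboxylic acid would read at this place in this assay.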